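The source may hold more compounds than are shown below. What is called first, only, known or untested is meant among the compounds shown, and "the series" means these compounds.

Compound 1 `O=C(/C=C/c1ccc(F)cc1)O/C(=N/C1CCCCC1)NC1CCCCC1`: 85.5%
Compound 2 `Cc1ccc(/C=C/C(=O)O/C(=N/C2CCCCC2)NC2CCCCC2)cc1`: 95.5%
Compound 3 `COC(=O)[C@@H]1COC(/C=C/c2ccc(OC)cc2)=N1`: 20.9%

In an ADME assay on Vero cells (Chlorocebus sabaeus) for cytotoxicity, read by WST assay, tested at 100 ug/mL (on this read-out lower numbers stand for a stronger effect and higher numbers for a weaker effect at the one concentration tested), compound 3 stands lowest of the three numbers, far from compound 1 and further still from compound 2, both gaps beyond the scatter. Going by the values given here, the only measured step, a number 10 percentage points higher from compound 1 to compound 2 (within the scatter), lies within the scatter and concerns a different pair and a different change, so it gives no direct guide. Compound 4 `COC(=O)[C@@H]1COC(/C=C/c2ccccc2)=N1` differs from compound 3 by hydrogen in place of methoxy on an aromatic carbon. Among the compounds with values here, with no closely related step to lean on, the expected change is small and uncertain, stated as a number 9.1 percentage points higher from compound 3 to compound 4 (within the scatter). For compound 4 the estimate is 30%, with a range from 10% to 60%.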

Compound 4, a percentage reported as activity, at one concentration (the size of the read-out at that concentration, not a potency): 12.4%
For compound 4 the middle estimate is 17.6 percentage points above the measured one, and the stated range covers the measured number.
By their numbers in this assay, from the lowest: compounds 4 and 3 (each within the scatter of the next); then compounds 1 and 2 (each within the scatter of the next).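

In this assay, hydrogen in place of methoxy on an aromatic carbon, para to a large group, gives a number 8.5 percentage points lower from compound 3 to compound 4 (within the scatter). Going by these compounds alone, the methoxy is therefore not needed at this position for the low number seen with compound 3, something the earlier compounds could not show. No measurement bears on what lies behind this result. On these data alone, whether an amine or a carboxylic acid at this position would shift the number beyond the scatter remains open. So does whether hydrogen at this position would read alike on the core of compound 1.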